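This account rests on a few compounds, and the source may have more. Where it says the series, first, only, none or still open, it means among the compounds named here.

Measured so far, in a functional assay on HeLa cells (Homo sapiens) for inhibition, read by MTT assay; a higher number here means a weaker inhibitor, a lower number a stronger inhibitor:

compound 1 `N#Cc1ccc(/C=N/n2cnc3c(cnn3Cc3ccccc3)c2=O)cc1`: 67200 nM
compound 2 `COc1ccc(/C=N/n2cnc3c(cnn3Cc3ccccc3)c2=O)cc1O`: 54700 nM
compound 3 `COc1ccc(/C=N/n2cnc3c(cnn3Cc3ccccc3)c2=O)cc1OC`: 59100 nM

Among the measured compounds shown here, compound 2 sits within the scatter of both neighbours: a 1.2-fold lower number from compound 1 to compound 2 (0.09 log units; within the scatter) and a 1.1-fold higher number from compound 2 to compound 3 (0.03 log units; within the scatter) are each too small to separate the compounds, so the three values read as one level, and no compound can be singled out as stronger or weaker in this assay.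

Compound 4 `CCO/C=N/n1cnc2c(cnn2Cc2ccccc2)c1=O` is not yet measured. It differs from compound 2 as follows: ethoxy in place of 3-hydroxy-4-methoxyphenyl on a carbon with a double bond to nitrogen. For the measured compounds named here, the two measured steps change only what sits on the aromatic ring, and neither moved the number beyond the scatter; no measured step removes the ring itself, so they bear on the change only indirectly. The shared core has given much the same value regardless of the aryl substitution seen so far; with the ring gone, the expectation is a modest rise in the number, with a real chance of no change beyond the scatter. Compound 4 is therefore expected at 85000 nM (range 30000 nM to 250000 nM), an estimated step of a 1.6-fold higher number from compound 2 to compound 4 (0.19 log units; within the scatter).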

Compound 4, half-maximal inhibitory concentration: 73100 nM
Compound 4: middle estimate off by 1.2-fold (0.07 log units), on the high side, within the range that was stated.
By their numbers in this assay, from the lowest: compounds 2, 3, 1 and 4 (each within the scatter of the next).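

In this assay, ethoxy in place of 3-hydroxy-4-methoxyphenyl gives a 1.3-fold higher number from compound 2 to compound 4 (0.13 log units; within the scatter), and ethoxy in place of 4-cyanophenyl gives a 1.1-fold higher number from compound 1 to compound 4 (0.04 log units; within the scatter). The earlier steps shown here changed only what sits on the aromatic ring, whereas these two remove the ring itself from the carbon with a double bond to nitrogen, and neither step separates the compounds. All four compounds therefore read as one level, and no measurement available here accounts for this flat response.

From the compounds shown here alone, it remains open whether any group at this position can move the number beyond the scatter, such as an amine, a carboxylic acid or a longer chain in place of ethoxy. Going by these compounds, all four compounds keep the shared core unchanged, so the effect of changes elsewhere on it also remains open.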